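Swapping a Butyl Chain for an Oxane Amide

This account rests on a few compounds, and the source may have more. Where it says the series, first, only, none or still open, it means among the compounds named here.

Compound 1 `CCCCN1CCc2nc(C#Cc3ccccc3)sc2C1` carries a butyl on the amine nitrogen of its shared core. In an assay on HEK293 cells for negative allosteric modulation of metabotropic glutamate receptor 5 (Homo sapiens), read by FLIPR, with a stated time of 1 h (on this read-out lower numbers stand for stronger inhibition and higher numbers for weaker inhibition), compound 1 gives > 10000 nM, a limit of the assay. Compound 2 `O=C(C1CC12CCC2)N1CCc2nc(C#Cc3ccccc3)sc2C1` gives > 10000 nM, again a limit. Compound 3 `O=C(C1CCCO1)N1CCc2nc(C#Cc3ccccc3)sc2C1` gives > 10000 nM, also a limit. The steps a step that the two limits leave unreadable from compound 1 to compound 2, a step that the two limits leave unreadable from compound 1 to compound 3 and a step that the two limits leave unreadable from compound 2 to compound 3 therefore cannot be sized; (the limit of > 10000 nM in this assay, at which 3 of the 3 values shown sit). Compound 4 `O=C(C1CCOCC1)N1CCc2nc(C#Cc3ccccc3)sc2C1` differs from compound 1 by (oxan-4-yl)carbonyl in place of butyl on an amine nitrogen in a ring. The measured steps bear on this change only in that each exchange at this nitrogen so far left the reading at the limit, so for compound 4 the expected step is a step that the limit leaves unreadable from compound 1 to compound 4, with no readable direction. Compound 4 is thus estimated at 20000 nM, with a likely range from 8000 nM to 60000 nM.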

Compound 4, half-maximal inhibitory concentration: > 10000 nM
Compound 4: no number, only a limit; the forecaster's own chance of this, stated with the estimate: 80%; the middle value is on the limit's open side.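

Compound 4 also reads only as a limit in this assay, so its steps from compound 1, compound 2 and compound 3 cannot be read: (the limit of > 10000 nM in this assay, at which 4 of the 4 values shown sit). The compounds shown leave open how strongly each inhibits, and whether any exchange on the amine nitrogen changes that.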